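A few compounds are considered here, and "the series" means these few. Any claim that something is new, unique, unknown or untested is made for them only; others in the source may bear on it.

In a functional assay on NCI/ADR cells (Homo sapiens) for inhibition, read by sulforhodamine B assay, with a stated time of 48 h (a higher number here means a weaker inhibitor of growth, a lower number a stronger inhibitor of growth), compound 2 `O=C1C=CCC(/C=C/c2ccccc2)N1` gives 967 uM, the highest of the three numbers measured, while compound 1 `O=C1C=CCC(/C=C/c2ccccc2C(F)(F)F)O1` gives 75.5 uM and compound 3 `O=C1C=CCC(/C=C/c2ccccc2C(F)(F)F)N1` gives 40.6 uM. The unmeasured compound 4 `O=C1C=CCC(/C=C/c2ccc(C(F)(F)F)cc2)N1` differs from compound 2 by trifluoromethyl in place of hydrogen on an aromatic carbon. Going by the values given here, only one measured step involves the same group entering the same ring, and it gave a 24-fold lower number from compound 2 to compound 3 (1.38 log units; beyond the scatter), a large lowering of the number. Among the compounds with values here, no measured pair shows the group at the place it occupies in compound 4, so the step is expected to run in the same direction but is taken as somewhat smaller. Compound 4 is therefore estimated at 90 uM, with a likely range from 20 uM to 400 uM. The expected step is then an 11-fold lower number from compound 2 to compound 4 (1.03 log units; beyond the scatter).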

Compound 4, concentration for growth inhibition (reported as GI): 71.8 uM
Compound 4: middle estimate off by 1.3-fold (0.10 log units), on the high side; low and high end bracket the measured number.
By their numbers in this assay, from the lowest: compounds 3, 4 and 1 (each within the scatter of the next); then compound 2.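

In this assay, trifluoromethyl para to a group of 9 heavy atoms gives a 13-fold lower number from compound 2 to compound 4 (1.13 log units; beyond the scatter), so the large lowering is not confined to the place the group holds in compound 3, where the step was a 24-fold lower number from compound 2 to compound 3 (1.38 log units; beyond the scatter). Compounds 3 and 4 lie within the scatter of each other, so these two places cannot be told apart here. Nothing available explains why this change lowers the number.

The compounds shown leave open whether a chlorine atom or a methoxy group at this place would lower the number as well. They also leave open whether the lowering holds with the core of compound 1.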